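Serine phosphate esters: methyl branch on the linker chain

A few compounds are considered here, and "the series" means these few. Any claim that something is new, unique, unknown or untested is made for them only; others in the source may bear on it.

Three compounds of the series have been examined in an assay on HEK293 cells for agonist activity at putative P2Y purinoceptor 10 (Mus musculus), with a stated time of 1 h; on this read-out higher numbers stand for larger maximal responses and lower numbers for smaller maximal responses. Compound 1 `CCCCCCCC/C=C\CCCCCCCC(=O)OC[C@@H](COCC)OP(=O)(O)OC[C@H](N)C(=O)O` is reported as "not active" (no number reported), so it contributes no number. Compound 2 `CCCCCCCC/C=C\CCCCCCCC(=O)OC[C@@H](COCc1ccccc1)OP(=O)(O)OC[C@H](N)C(=O)O` gives 7.3%. Compound 3 `N[C@@H](COP(=O)(O)OCCOC(=O)CCc1ccccc1OCc1cccc(Oc2ccccc2)c1)C(=O)O` gives 20.8%, the higher of the two numbers, and its gap to compound 2 lies beyond the scatter. For the measured compounds named here, no two measured compounds differ in only one place, so no measured step is available to anchor the next change.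

Compound 4 `C[C@H](COP(=O)(O)OC[C@H](N)C(=O)O)OC(=O)CCc1ccccc1OCc1cccc(Oc2ccccc2)c1` follows from compound 3 by a single change: methyl in place of hydrogen on a saturated chain carbon bound to an oxygen next to a carbonyl group and a saturated chain carbon. The change is a methyl in place of hydrogen on a saturated chain carbon bound to an oxygen next to a carbonyl group and a saturated chain carbon; all other parts are kept. Going by the values given here, the data hold no step of this kind, so a movement beyond the scatter in either direction is not expected. Compound 4 is therefore expected to give 22%, within 8% to 40%. The expected step of a number 1.2 percentage points higher from compound 3 to compound 4 (within the scatter) is none beyond the scatter.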

Compound 4, largest response reached (Emax), in percent of the reference or control that the assay uses: 13.8%
Estimate against measurement, compound 4: 8.2 percentage points above; the range from low to high includes it.
By their numbers in this assay, from the lowest: compounds 2, 4 and 3 (each within the scatter of the next, the first and the last beyond it).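

For the compounds shown here, this is the first step between compounds that differ in one place: in this assay methyl in place of hydrogen on a saturated chain carbon bound to an oxygen next to a carbonyl group and a saturated chain carbon gives a number 7 percentage points lower from compound 3 to compound 4 (within the scatter) on the maximal response. This position therefore accepts a methyl without a movement beyond the scatter, so the branch leaves the response of compound 3 in place on this read-out. Nothing available bears on this step or accounts for it.

Still open, from the compounds shown here alone, is whether a longer chain at this carbon, such as an ethyl or propyl group, also stays within the scatter of compound 3. Equally open, going by these compounds, is how a hydroxyl group or an amine at the same carbon would compare with the methyl of compound 4.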